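Acetyl in Place of Methyl on a Smaller Ring

This account rests on a few compounds, and the source may have more. Where it says the series, first, only, none or still open, it means among the compounds named here.

Three compounds have been measured in an assay on lysate for inhibition of 6-phosphofructo-2-kinase/fructose-2,6-bisphosphatase 3 (Homo sapiens), with stated times of 0.5 min and 45 min; on this read-out higher numbers stand for weaker inhibition and lower numbers for stronger inhibition:

Compound 1, `CN1CCC(NC(=O)c2ccncc2Nc2cc(-c3ccc4ccn(C)c4c3)c3nccnc3c2)CC1`, gives 19500 nM.
Compound 2, `CC(=O)N1CCC(NC(=O)c2ccncc2Nc2cc(-c3ccc4ccn(C)c4c3)c3nccnc3c2)CC1`, gives 31300 nM.
Compound 3, `CN1CC(NC(=O)c2ccncc2Nc2cc(-c3ccc4ccn(C)c4c3)c3nccnc3c2)C1`, gives 9190 nM.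

Compound 1 and compound 2 differ by one change, (acetyl in place of methyl on an amine nitrogen in a ring), and this change gave a 1.6-fold higher number from compound 1 to compound 2 (0.21 log units; within the scatter). Compound 3 carries a different core from compound 1; the difference is 1-methylazetidin-3-yl in place of 1-methylpiperidin-4-yl on an amide-type nitrogen, which gave a 2.1-fold lower number from compound 1 to compound 3 (0.33 log units; beyond the scatter). Between compound 2 and compound 3 the gap is a 3.4-fold lower number from compound 2 to compound 3 (0.53 log units; beyond the scatter). Compound 3 thus gives the lowest number of the three.

Compound 4, `CC(=O)N1CC(NC(=O)c2ccncc2Nc2cc(-c3ccc4ccn(C)c4c3)c3nccnc3c2)C1`, has not yet been measured. It stands to compound 3 as compound 2 stands to compound 1: acetyl in place of methyl on an amine nitrogen in a ring. The surroundings are not identical, though. In compound 1 the change sits on an amine nitrogen in a ring of a six-membered non-aromatic ring with 1 nitrogen, three ring bonds from the ring atom that bears a large group; in compound 3 it sits on an amine nitrogen in a ring of a four-membered non-aromatic ring with 1 nitrogen, two ring bonds from that ring atom. It is therefore the same kind of change, not the same change.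

Among the measured compounds shown here, with only one earlier example, the step from compound 3 to compound 4 is expected to be about a 1.6-fold higher number from compound 3 to compound 4 (0.20 log units; within the scatter), resting on the fact that compound 1 to compound 2 gave a 1.6-fold higher number from compound 1 to compound 2 (0.21 log units; within the scatter). Compound 4 is therefore estimated at 14500 nM, with a range from 6000 nM to 35000 nM.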

Compound 4, half-maximal inhibitory concentration in the 6-phosphofructo-2-kinase/fructose-2,6-bisphosphatase 3 assay: 97400 nM
Compound 4: the middle estimate sits 6.7-fold (0.83 log units) below what was measured; measured number outside the range, above it.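

The same change, acetyl in place of methyl, gives steps of different size on the two cores: the same change on two cores in the 6-phosphofructo-2-kinase/fructose-2,6-bisphosphatase 3 assay, a 1.6-fold higher number (0.21 log units; within the scatter) from compound 1 to compound 2 and an 11-fold higher number (1.03 log units; beyond the scatter) from compound 3 to compound 4, 6.6-fold (0.82 log units) apart, beyond the scatter of two such steps

On the four-membered ring, the 6-phosphofructo-2-kinase/fructose-2,6-bisphosphatase 3 assay shows a large loss of inhibition, an 11-fold higher number from compound 3 to compound 4 (1.03 log units; beyond the scatter), and compound 4 has the weakest inhibition of the four, with the 6-phosphofructo-2-kinase/fructose-2,6-bisphosphatase 3 assay giving a 3.1-fold higher number from compound 2 to compound 4 (0.49 log units; beyond the scatter) and a 5.0-fold higher number from compound 1 to compound 4 (0.70 log units; beyond the scatter). The ring swap itself also depends on the group on the ring nitrogen: with methyl, the 6-phosphofructo-2-kinase/fructose-2,6-bisphosphatase 3 assay gives a 2.1-fold lower number from compound 1 to compound 3 (0.33 log units; beyond the scatter), whereas with acetyl the same swap goes the other way, as the step to compound 4 from compound 2 shows. Among the compounds shown here, this pattern rests on only two pairs of compounds, so it does not show why the steps differ, and it gives no rule for predicting the change on a third core. In a physicochemical assay for solubility, read by spectrophotometry, measured as kinetic solubility, at pH 8, tested at 500 uM (on this read-out higher numbers stand for higher solubility and lower numbers for lower solubility), compound 3 gives 170 ug/mL and compound 4 gives 244 ug/mL (a 1.4-fold higher number from compound 3 to compound 4 (0.16 log units; within the scatter)).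

The compounds shown leave open what a free amine, with only hydrogen on the ring nitrogen, would do on these two cores. They also leave open whether a longer chain on that nitrogen, such as ethyl or propanoyl, would follow the methyl compounds or the acetyl compounds.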